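This account rests on a few compounds, and the source may have more. Where it says the series, first, only, none or still open, it means among the compounds named here.

Compound 2 `Nc1scc(CN2CCN(C3CCCCC3)CC2)c1C(=O)c1ccc(Cl)cc1` gives 1.9 nM in an assay on CHO cells for displacement of a labelled ligand from adenosine receptor A1 (Homo sapiens) (on this read-out lower numbers stand for tighter binding and higher numbers for weaker binding), and compound 1 `CN1CCN(Cc2csc(N)c2C(=O)c2ccc(Cl)cc2)CC1` gives 1.7 nM; these two numbers lie within the scatter of each other, so compound 2 does not stand apart from compound 1. Compound 3 `Nc1scc(CN2CCN(c3ccccc3)CC2)c1C(=O)c1ccc(Cl)cc1` differs from compound 2 by phenyl in place of cyclohexyl on an amine nitrogen in a ring. Among the compounds with values here, the only step seen at this ring nitrogen, a 1.1-fold higher number from compound 1 to compound 2 (0.05 log units; within the scatter), hardly moved the number. A similarly small change is therefore expected here, estimated as a 1.6-fold higher number from compound 2 to compound 3 (0.20 log units; within the scatter), with no firm direction. Compound 3 is expected to give about 3 nM in this assay, in a range from 0.8 nM to 12 nM.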

Compound 3, dissociation constant: 1.9 nM
For compound 3 the middle estimate is 1.6-fold (0.20 log units) above the measured one; the range from low to high includes it.
By their numbers in this assay, from the lowest: compounds 1, 2 and 3 (each within the scatter of the next).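

Putting phenyl in place of cyclohexyl gives no change at the digits printed from compound 2 to compound 3 (within the scatter) in this assay, so at this ring nitrogen an aromatic six-carbon ring and a non-aromatic one cannot be told apart. Phenyl in place of methyl gives a 1.1-fold higher number from compound 1 to compound 3 (0.05 log units; within the scatter) as well, which places methyl, cyclohexyl and phenyl all within the scatter of one another. No measurement here explains this tolerance. Still open, going by these compounds, is whether a hydrogen alone, or a chain ending in an amine or a carboxylic acid, would behave the same way on this nitrogen.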